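Replacing the Aryl Group on the Carbonyl of Compound 1

The compounds below may be only part of what the source reports. "The series", "measured", "known", "first", "only" and "open" are said of these compounds alone.

Within the data shown here, in a functional assay on DLA cells (Mus musculus) for cytotoxicity, read by LDH release, with a stated time of 48 h (a higher number here means a weaker inhibitor, a lower number a stronger inhibitor), compound 1 `Cc1cc(C(=O)c2ccc(F)cc2)ccc1OCC(=O)Nc1nc(-c2ccccc2)cs1` gives 34700 nM, the higher of the two numbers measured so far. Compound 2 `COc1ccc(-c2csc(NC(=O)COc3ccc(C(=O)c4ccc(F)cc4)cc3C)n2)cc1` gives 5500 nM. Among the measured compounds shown here, the one measured step, a 6.3-fold lower number from compound 1 to compound 2 (0.80 log units; beyond the scatter), is modest but beyond the scatter, and it is methoxy in place of hydrogen on an aromatic carbon.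

Compound 3 `Cc1cc(C(=O)c2ccccc2C)ccc1OCC(=O)Nc1nc(-c2ccccc2)cs1` has not yet been measured. Its difference from compound 1 is 2-methylphenyl in place of 4-fluorophenyl on a carbonyl carbon. For the measured compounds named here, no measured step covers this change, so the step to compound 2 serves only as a loose gauge of how far one change has moved the number in this assay. The data give no firm direction. Since compound 1 already holds the higher number, a small shift towards a lower number is expected, most likely within the scatter. The expected step is a 1.3-fold lower number from compound 1 to compound 3 (0.11 log units; within the scatter). For compound 3 the estimated value is 27000 nM, with an expected range of 9000 nM to 75000 nM.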

Compound 3, half-maximal inhibitory concentration: 23700 nM
For compound 3 the middle estimate is 1.1-fold (0.06 log units) above the measured one; low and high end bracket the measured number.
By their numbers in this assay, from the lowest: compound 2; then compounds 3 and 1 (each within the scatter of the next).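

In this assay, the carbonyl carbon's aryl group is varied for the first time among these compounds, and 2-methylphenyl in place of 4-fluorophenyl gives a 1.5-fold lower number from compound 1 to compound 3 (0.17 log units; within the scatter). The two groups match in heavy-atom count and in having no hydrogen-bond donors or acceptors, and this assay does not separate them, whereas methoxy in place of hydrogen on an aromatic carbon gave a 6.3-fold lower number from compound 1 to compound 2 (0.80 log units; beyond the scatter). No accompanying measurement speaks to the reason for this result.

It remains open whether a group of a different kind on the carbonyl carbon, such as a morpholine ring or a phenyl ring carrying a carboxylic acid, would move the number beyond the scatter, since 4-fluorophenyl and 2-methylphenyl are the only two groups shown at this place. Going by these compounds, it is also open whether methoxy in place of hydrogen on the same aromatic carbon would give a similar step when 2-methylphenyl sits on the carbonyl carbon, as the methoxy step is known only with 4-fluorophenyl there.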